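Acetyl to Dimethylamino on a Shared Pyrazole Core

A few compounds are considered here, and "the series" means these few. Any claim that something is new, unique, unknown or untested is made for them only; others in the source may bear on it.

Measured compounds:
compound 1 `COc1cc(C)cc(-c2c(-c3ccnc(-c4ccc(C(C)=O)cc4)c3)cnn2CC#N)c1` — -78%
compound 2 `Cc1cc(O)cc(-c2nn(CC#N)cc2-c2ccnc(-c3ccc(Oc4ccccc4)cc3)c2)c1` — -94%

Of the compounds shown here, two have been measured in a functional assay on COLO 205 cells (Homo sapiens) for cytotoxicity, read by sulforhodamine B assay, with a stated time of 48 h, tested at 1 uM; on this read-out lower numbers stand for a stronger effect and higher numbers for a weaker effect at the one concentration tested. Compound 1 `COc1cc(C)cc(-c2c(-c3ccnc(-c4ccc(C(C)=O)cc4)c3)cnn2CC#N)c1` gives -78%, and compound 2 `Cc1cc(O)cc(-c2nn(CC#N)cc2-c2ccnc(-c3ccc(Oc4ccccc4)cc3)c2)c1` gives -94%. Of these two numbers, the value of compound 1 is the higher one, and the gap to compound 2 lies beyond the usual scatter of the measurement. Within the data shown here, the two compounds differ in more than one place, so no single step between them can be read from the numbers.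

The account now turns to compound 3 `COc1cc(C)cc(-c2c(-c3ccnc(-c4ccc(N(C)C)cc4)c3)cnn2CC#N)c1`, which has not yet been tested. Compound 3 differs from compound 1 in one place: dimethylamino in place of acetyl on an aromatic carbon. The acetyl leaves and a dimethylamino enters, so that the 4-acetylphenyl of compound 1 becomes the 4-(dimethylamino)phenyl of compound 3, para to a large group.

Among the measured compounds shown here, no measured pair shows what this exchange does in this assay, so the expected step is uncertain in direction. Compound 3 is expected to give about -72%, within a range from -92% to -40%. The expected step of a number 6 percentage points higher from compound 1 to compound 3 (within the scatter) is estimated to stay within the scatter.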

Compound 3, a percentage reported as activity, at one concentration (the size of the read-out at that concentration, not a potency): 3%
The estimate for compound 3 lay 75 percentage points below the measured number; measured number above the stated range.
By their numbers in this assay, from the lowest: compound 2; then compound 1; then compound 3.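

In this assay, placing dimethylamino instead of acetyl on this aromatic carbon, para to a large group, gives a number 81 percentage points higher from compound 1 to compound 3 (beyond the scatter), the first step read at this position, and it shows that the effect at this one concentration depends strongly on the group held there. The change is a weakening, and the counts do not separate the two groups: each has 3 heavy atoms, 1 hydrogen-bond acceptor, no hydrogen-bond donor, no ring and no net charge, while acetyl alone has a double bond outside the aromatic rings. Nothing measured on these compounds says what lies behind so large a step from so small a change in these counts.

The compounds shown leave open whether the weakening follows from the nitrogen attached to the aromatic ring or from the loss of the carbonyl, which a primary amine, a methoxy group or a carboxylic acid at the same place could help to separate. The phenoxy group of compound 2 sits on the same phenyl ring, but that compound also differs elsewhere, so its value cannot be used to settle the point.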